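The compounds below may be only part of what the source reports. "The series", "measured", "known", "first", "only" and "open" are said of these compounds alone.

Measured in a functional assay on HCT-116 cells (Homo sapiens) for inhibition, read by MTT assay, with a stated time of 72 h; on this read-out lower numbers stand for stronger inhibition and higher numbers for weaker inhibition:
- compound 1 `O=C1/C(=C\c2ccccc2)c2c(ncn2COCc2ccccc2)CCN1Cc1ccccc1`: 20000 nM
- compound 2 `O=C1/C(=C\c2ccccc2)c2c(ncn2COCc2ccccc2)CCN1Cc1ccc(-c2ccccc2)cc1`: 14000 nM
- compound 3 `CC(C)(C)c1ccc(CN2CCc3ncn(COCc4ccccc4)c3/C(=C/c3ccccc3)C2=O)cc1`: 8460 nM

Compound 1 holds the top number of the three, level within the scatter with compound 2 and separated beyond it from compound 3.

Next in the series is compound 4 `O=C1/C(=C\c2ccc(C(F)(F)F)cc2)c2c(ncn2COCc2ccccc2)CCN1Cc1ccccc1`, which differs from compound 1 by trifluoromethyl in place of hydrogen on an aromatic carbon, para to a large group.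

Among the measured compounds shown here, no measured step makes this change, and the measured substitutions sit on a different aromatic ring, so they bear only indirectly. They are a 1.4-fold lower number from compound 1 to compound 2 (0.15 log units; within the scatter) and a 2.4-fold lower number from compound 1 to compound 3 (0.37 log units; beyond the scatter), while a 1.7-fold lower number from compound 2 to compound 3 (0.22 log units; within the scatter). Added groups have so far moved the number little, and only the tert-butyl step clears the scatter, modestly. A small step towards a lower number is therefore expected, probably not beyond the scatter.

The expected step is a 1.5-fold lower number from compound 1 to compound 4 (0.19 log units; within the scatter).

For compound 4 the estimated value is 13000 nM, with an expected range of 5500 nM to 28000 nM.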

Compound 4, half-maximal inhibitory concentration: 36000 nM
For compound 4 the middle estimate is 2.8-fold (0.44 log units) below the measured one; measured number above the stated range.
By their numbers in this assay, from the lowest: compounds 3, 2, 1 and 4 (each within the scatter of the next, the first and the last beyond it).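

In this assay the change from phenyl to 4-(trifluoromethyl)phenyl gives a 1.8-fold higher number from compound 1 to compound 4 (0.26 log units; within the scatter) and leaves compound 4 level with compound 1. This is the only reading shown on this aromatic ring, and it does not repeat the step beyond the scatter seen on the other aromatic ring, a 2.4-fold lower number from compound 1 to compound 3 (0.37 log units; beyond the scatter), so that step cannot be assumed to carry over to this ring. Nothing measured here offers an explanation for this result.

On these data alone, one substituent at one place gives no trend for this ring, so it remains open whether a group such as an amine, a carboxylic acid or a methoxy group would separate from compound 1 beyond the scatter. Also open, as far as these compounds go, is whether trifluoromethyl and tert-butyl would combine on the same core in any simple way.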